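The source may hold more compounds than are shown below. What is called first, only, known or untested is meant among the compounds shown, and "the series" means these compounds.

The measured pair: compound 1 `CCN1CCN(C(=S)SCC(=O)N(Cc2ccc(OC)cc2)c2cc(OC)c(OC)c(OC)c2)CC1` gives 7700 nM in a functional assay on HCT-116 cells (Homo sapiens) for inhibition, read by CCK-8 assay, with a stated time of 48 h; on this read-out lower numbers stand for stronger inhibition and higher numbers for weaker inhibition; compound 2 `COc1ccc(CN(C(=O)CSC(=S)N2CCc3ccccc32)c2cc(OC)c(OC)c(OC)c2)cc1` gives 7710 nM in this assay.

Compound 1 holds the lowest of the two numbers, but its nearest neighbour is compound 2, and the step of a 1.0-fold higher number from compound 1 to compound 2 (0.00 log units; within the scatter) lies within the scatter, so the two compounds cannot be told apart on these data. That step is also the only one that bears on the change to compound 3: in both cases the 4-ethylpiperazin-1-yl on the thiocarbonyl carbon gives way to a nitrogen ring fused to a benzene ring, the first time as 2,3-dihydro-1H-indol-1-yl, now as the larger 6-methoxy-1,2,3,4-tetrahydroquinolin-1-yl.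

Compound 3 `COc1ccc(CN(C(=O)CSC(=S)N2CCCc3cc(OC)ccc32)c2cc(OC)c(OC)c(OC)c2)cc1` differs from compound 1 as follows: 6-methoxy-1,2,3,4-tetrahydroquinolin-1-yl in place of 4-ethylpiperazin-1-yl on a thiocarbonyl carbon. For the measured compounds named here, since the one comparable step, from compound 1 to compound 2, was flat, the same is expected here, and no step beyond the scatter is anticipated in this assay; the expected step is no change at the digits printed from compound 1 to compound 3 (within the scatter). Compound 3 is therefore estimated at 7700 nM, with a range from 3500 nM to 17000 nM.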

Compound 3, half-maximal inhibitory concentration: > 20000 nM
Compound 3: no number, only a limit (the forecaster's own chance of this, stated with the estimate: 5%); at least 2.5-fold (0.41 log units) between middle value and limit.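

The place on a thiocarbonyl carbon is not indifferent to what stands on it: 6-methoxy-1,2,3,4-tetrahydroquinolin-1-yl in place of 4-ethylpiperazin-1-yl gives an at least 2.5-fold higher number from compound 1 to compound 3 (0.41 log units; beyond the scatter), and the same group in place of 2,3-dihydro-1H-indol-1-yl gives an at least 2.5-fold higher number from compound 2 to compound 3 (0.41 log units; beyond the scatter). The earlier pair had shown no such sensitivity, with a 1.0-fold higher number from compound 1 to compound 2 (0.00 log units; within the scatter), so a nitrogen ring fused to a benzene ring is not tolerated here as a class, and the two such groups shown do not behave alike. The result for compound 3 in this assay is a limit and not a number, so both new steps give only a lower bound on the size of the change: the limit of > 20000 nM in this assay, at which 1 of the 3 values shown sits.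

The compounds shown leave open whether the difference goes with the methoxy group or with the ring that carries it, since the plain 1,2,3,4-tetrahydroquinolin-1-yl, without the methoxy group, would separate the two. On these data alone, it also remains open how a morpholin-4-yl or a piperidin-1-yl on the thiocarbonyl carbon would read in this assay.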